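A few compounds are considered here, and "the series" means these few. Any claim that something is new, unique, unknown or untested is made for them only; others in the source may bear on it.

The series shares one core and varies the group on the nitrogen on an aromatic ring. In a functional assay on BT-549 cells (Homo sapiens) for cytotoxicity, read by sulforhodamine B assay, with a stated time of 72 h (on this read-out lower numbers stand for stronger inhibition and higher numbers for weaker inhibition), compound 1 `CCS(=O)(=O)Nc1cc(-c2ccc3ncnc(Nc4cccc(F)c4)c3c2)cnc1OC` gives 2760 nM, compound 2 `CCS(=O)(=O)Nc1cc(-c2ccc3ncnc(Nc4cccc(C(=O)OC)c4)c3c2)cnc1OC` gives 1080 nM, and compound 3 `CCS(=O)(=O)Nc1cc(-c2ccc3ncnc(Nc4ccc(Cl)c(C(=O)OC)c4)c3c2)cnc1OC` gives 2360 nM. Among these three numbers compound 3 stands second highest; its nearest neighbour is compound 1, separated by a gap within the scatter, while the step of a 2.2-fold higher number from compound 2 to compound 3 (0.34 log units; beyond the scatter) is the only one that sets it apart beyond the scatter. Compound 4 `CCS(=O)(=O)Nc1cc(-c2ccc3ncnc(Nc4ccc(OC)nc4)c3c2)cnc1OC` carries the change (6-methoxypyridin-3-yl in place of 4-chloro-3-(methoxycarbonyl)phenyl on a nitrogen on an aromatic ring). The measured steps that bear on it are those which alter the same group on that nitrogen: a 1.2-fold lower number from compound 1 to compound 3 (0.07 log units; within the scatter) and a 2.6-fold lower number from compound 1 to compound 2 (0.41 log units; beyond the scatter), neither more than modest. Among the compounds with values here, no measured step replaces this ring with a ring bearing a hetero atom, so the direction cannot be read from the data. The expected step of a 1.1-fold higher number from compound 3 to compound 4 (0.03 log units; within the scatter) is therefore set at the edge of the scatter. Compound 4 is estimated at 2500 nM, with a range from 900 nM to 7000 nM.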

Compound 4, half-maximal inhibitory concentration: 3490 nM
Compound 4: middle estimate off by 1.4-fold (0.14 log units), on the low side; measured number inside the range.
By their numbers in this assay, from the lowest: compound 2; then compounds 3, 1 and 4 (each within the scatter of the next).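

A ring with a hetero atom, 6-methoxypyridin-3-yl, now sits on the nitrogen, and in this assay the steps of a 1.5-fold higher number from compound 3 to compound 4 (0.17 log units; within the scatter) and a 1.3-fold higher number from compound 1 to compound 4 (0.10 log units; within the scatter) both stay within the scatter, so this ring cannot be told apart from the 4-chloro-3-(methoxycarbonyl)phenyl or 3-fluorophenyl groups. Within the data shown here, only the step of a 3.2-fold higher number from compound 2 to compound 4 (0.51 log units; beyond the scatter) passes beyond the scatter, which leaves compound 2, with its 3-(methoxycarbonyl)phenyl group, as the one compound set apart, at the low end of the four numbers. Nothing measured alongside these numbers offers an explanation for the steps.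

Open, on these data alone, is whether an amine or a carboxylic acid in place of the methoxycarbonyl group of compound 2 would shift the number further. Also open, as far as these compounds go, is what the ring nitrogen and the methoxy group of compound 4 each contribute, which a plain pyridin-3-yl ring would help to separate.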